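Adding a 4-nitrophenyl group where compound 2 carries only hydrogen

The source may report more compounds than this note shows. Statements on the series, on what has been measured and on what is new or still open speak of the compounds shown alone.

Measured compounds:
compound 1 `COc1ccc(Cn2c(=O)n(C3OC(CO)[C@@H](O)[C@H]3O)c3nc(N)nc(O)c32)cc1` gives 135 uM
compound 2 `Cn1c(=O)n(C2OC(CO)[C@@H](O)[C@H]2O)c2nc(N)nc(O)c21` gives 10 uM

In a functional assay (B cells) with Mus musculus as the target (a higher number here means that more compound is needed for the effect, a lower number that less compound is needed), compound 2 shows the lowest of the two numbers; its nearest neighbour is compound 1, and the step of a 14-fold lower number from compound 1 to compound 2 (1.13 log units; beyond the scatter) was large. Compound 3 `Nc1nc(O)c2c(n1)n(C1OC(CO)[C@@H](O)[C@H]1O)c(=O)n2Cc1ccc([N+](=O)[O-])cc1` has not yet been measured. It differs from compound 2 by 4-nitrophenyl in place of hydrogen on a saturated chain carbon bound to an aromatic nitrogen, so a group of the same kind that compound 1 carries returns, now bearing a nitro group instead of a methoxy group. Within the data shown here, the only step that bears on this change is the one from compound 1 to compound 2, which took the aryl group away and brought a large drop. Running the same kind of change in reverse, a large rise is expected in this assay for compound 3, about a 10-fold higher number from compound 2 to compound 3 (1.00 log units; beyond the scatter). Compound 3 is therefore estimated at 100 uM, with a range from 30 uM to 350 uM.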

Compound 3, concentration for half-maximal effect: 40 uM
The estimate for compound 3 lay 2.5-fold (0.40 log units) above the measured number; low and high end bracket the measured number.
By their numbers in this assay, from the lowest: compound 2; then compound 3; then compound 1.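

In this assay, the rise seen with the 4-methoxyphenyl group is not confined to that one group: a second aryl group at this place also raises the number, a 4.0-fold higher number from compound 2 to compound 3 (0.60 log units; beyond the scatter), although by less. The group carried on the aromatic ring matters too, since nitro in place of methoxy on an aromatic carbon gives a 3.4-fold lower number from compound 1 to compound 3 (0.53 log units; beyond the scatter), so the two compounds with an aryl group are not interchangeable. The data shown offer no explanation for either step.

Among these compounds, with only two groups on that ring, no trend across ring groups can be drawn, and where plain benzyl or a ring carrying an amine or a carboxylic acid would fall remains open. Also open, from the compounds shown here alone, is whether a longer chain without a ring, such as butyl, would raise the number as the aryl groups do.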